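One Ring Swap on the Amide Nitrogen

The compounds below may be only part of what the source reports. "The series", "measured", "known", "first", "only" and "open" are said of these compounds alone.

Measured so far:
Compound 1, `CCOC(=O)C1=Cc2ccccc2OC1(OCc1cn(CC(=O)Nc2ccc(C)cc2)nn1)C(F)(F)F`, gives 54300 nM.
Compound 2, `CCCCCCCCn1cc(COC2(C(F)(F)F)Oc3ccccc3C=C2C(=O)OCC)nn1`, gives > 150000 nM, which is a limit of the assay rather than a number.
Compound 3, `CCOC(=O)C1=Cc2ccccc2OC1(OCc1cn(CC(=O)Nc2ccc(OC)cc2)nn1)C(F)(F)F`, gives 29400 nM.

All these values come from a functional assay on A549 cells (Homo sapiens) for inhibition, read by MTT assay, with a stated time of 24 h; on this read-out higher numbers stand for weaker inhibition and lower numbers for stronger inhibition. Compound 3 holds the lowest of the two plain numbers, with compound 1 nearest: a 1.8-fold lower number from compound 1 to compound 3 (0.27 log units; within the scatter), which is within the scatter. Compound 2 sits at the limit (the limit of > 150000 nM in this assay, at which 1 of the 3 values shown sits). The step of an at least 5.1-fold lower number from compound 2 to compound 3 (0.70 log units; beyond the scatter) is beyond the scatter, as is an at least 2.7-fold higher number from compound 1 to compound 2 (0.44 log units; beyond the scatter).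

Compound 4, `CCOC(=O)C1=Cc2ccccc2OC1(OCc1cn(CC(=O)Nc2ccccc2F)nn1)C(F)(F)F`, keeps the shared core and the amide but changes the ring on the amide-type nitrogen: 2-fluorophenyl in place of 4-methoxyphenyl on an amide-type nitrogen. Two kinds of measured step bear on this position: replacing the (4-methylphenyl)carbamoyl group with heptyl raised the number clearly, while changing methyl to methoxy on the ring stayed within the scatter. An exchange of one aromatic ring for another resembles the second case, so the expected step of a 1.5-fold higher number from compound 3 to compound 4 (0.18 log units; within the scatter) is small, in either direction. Compound 4 is therefore estimated at 45000 nM, with a likely range from 15000 nM to 140000 nM.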

Compound 4, half-maximal inhibitory concentration: 50100 nM
The estimate for compound 4 lay 1.1-fold (0.05 log units) below the measured number; the range from low to high includes it.
By their numbers in this assay, from the lowest: compounds 3, 4 and 1 (each within the scatter of the next). At a limit, above all of these: compound 2.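

In this assay, a 1.7-fold higher number from compound 3 to compound 4 (0.23 log units; within the scatter) and a 1.1-fold lower number from compound 1 to compound 4 (0.03 log units; within the scatter), so the three aromatic rings on the amide-type nitrogen, 4-methylphenyl, 4-methoxyphenyl and 2-fluorophenyl, all give values within the scatter of one another. The separation from the heptyl compound also holds for this third ring, with an at least 2.9-fold lower number from compound 2 to compound 4 (0.47 log units; beyond the scatter). Compound 2 carries a limit of the assay and not a number: the limit of > 150000 nM in this assay, at which 1 of the 4 values shown sits.

As far as these compounds go, the step from heptyl changes both the amide and the ring at once, so it remains open which of the two parts carries the difference; cyclohexyl on the amide-type nitrogen would test the need for an aromatic ring. From the compounds shown here alone, it is also open whether a ring bearing an amine or a carboxylic acid would move the number beyond the scatter.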